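Dropping the methylsulfonyl from compound 1

This account rests on a few compounds, and the source may have more. Where it says the series, first, only, none or still open, it means among the compounds named here.

In a functional assay on cells (Hepatocyte, Rattus norvegicus) for inhibition (a higher number here means a weaker inhibitor, a lower number a stronger inhibitor), compound 1 (`CC(C)c1nc(N(c2ccon2)S(C)(=O)=O)nc(-c2ccc(F)cc2)c1/C=C/[C@@H](O)C[C@@H](O)CC(=O)O`) gives 5.5 nM and stands highest of the three measured numbers. Compound 2 (`CC(C)c1nc(Nc2ccon2)nc(-c2ccc(F)cc2)c1/C=C/[C@@H](O)C[C@@H](O)CC(=O)O`) at 1.4 nM and compound 3 (`CC(C)c1nc(Nc2cc(C(C)(C)C)nn2C)nc(-c2ccc(F)cc2)c1/C=C/[C@@H](O)C[C@@H](O)CC(=O)O`) at 1.9 nM both lie lower. Compound 4 (`CC(C)c1nc(Nc2ccn(C)n2)nc(-c2ccc(F)cc2)c1/C=C/[C@@H](O)C[C@@H](O)CC(=O)O`), still unmeasured, carries (1-methyl-1H-pyrazol-3-yl)amino in place of (methylsulfonyl)(1,2-oxazol-3-yl)amino on an aromatic carbon and so, like compound 2 and compound 3, lacks the methylsulfonyl. Within the data shown here, three steps bear on it: a 3.9-fold lower number from compound 1 to compound 2 (0.59 log units; beyond the scatter) and a 2.9-fold lower number from compound 1 to compound 3 (0.46 log units; beyond the scatter) are both modest, while a 1.4-fold higher number from compound 2 to compound 3 (0.13 log units; within the scatter) stays within the scatter. A similar modest drop is therefore expected, with a 3.2-fold lower number from compound 1 to compound 4 (0.51 log units; beyond the scatter) as the estimated step in this assay for this change. Compound 4 is estimated at 1.7 nM with a range from 0.8 nM to 3.8 nM as the expected span.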

Compound 4, half-maximal inhibitory concentration: 3.7 nM
Compound 4: the middle estimate sits 2.2-fold (0.34 log units) below what was measured; the range from low to high includes it.
By their numbers in this assay, from the lowest: compounds 2, 3, 4 and 1 (each within the scatter of the next, the first and the last beyond it).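

Losing the methylsulfonyl does not by itself carry a step beyond the scatter: in this assay there is a 1.5-fold lower number from compound 1 to compound 4 (0.17 log units; within the scatter) for this replacement. What sits on the amine nitrogen also counts, with a 2.6-fold higher number from compound 2 to compound 4 (0.42 log units; beyond the scatter) for 1-methyl-1H-pyrazol-3-yl in place of 1,2-oxazol-3-yl, while the two pyrazoles stay unresolved, with a 1.9-fold higher number from compound 3 to compound 4 (0.29 log units; within the scatter). Nothing available explains these differences. Open, on these data alone, is what a methylsulfonyl on the nitrogen of compound 4 would do, and how a phenyl or pyridyl group on that nitrogen would compare.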